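This account rests on a few compounds, and the source may have more. Where it says the series, first, only, none or still open, it means among the compounds named here.

Working notes on a small set of aryl nitrile compounds tested for antiproliferative activity in a functional assay on VCaP cells (Homo sapiens) for antiproliferative activity, read by CCK-8 assay, with a stated time of 6 days; on this read-out higher numbers stand for weaker inhibition and lower numbers for stronger inhibition. Compound 1 `N#Cc1ccc(N2CCc3cc(-c4cnc5ccccc5c4)ccc3C2)cc1C(F)(F)F` gives > 30000 nM in this assay, which is a limit of the assay and not a number. Compound 2 `Cc1noc(C)c1-c1cccc(Oc2ccc(C#N)c(C(F)(F)F)c2)c1` gives "not determined" (no result reported) in this assay. Compound 3 `CCN(c1ccc(C#N)c(Cl)c1)c1cc(-c2cccs2)ccc1C` likewise gives "not determined" (no result reported) in this assay. Compound 3 therefore stands nowhere on the numbers shown: it has no single value of its own, and neither of the other two entries supplies a number to set beside it. The only fixed point in this assay is the limit of > 30000 nM in this assay, at which 1 of the 3 values shown sits, which belongs to compound 1.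

Compound 4 `CCN(c1ccc(C#N)c(Cl)c1)c1cc(-c2cncnc2)ccc1C` is still to be measured in this assay. It differs from compound 3 by pyrimidin-5-yl in place of thiophen-2-yl on an aromatic carbon.

Among the compounds with values here, with no measured step anywhere in this assay and no number for compound 3, the size and direction of the move from compound 3 to compound 4 cannot be read from the data; no step beyond the scatter is assumed in this assay, and the direction is left open. Compound 4 is estimated at 3000 nM in this assay, with an expected range from 300 nM to 30000 nM, the width reflecting the absence of any numbered value in the set.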

Compound 4, half-maximal inhibitory concentration: 3920 nM
For compound 4 the middle estimate is 1.3-fold (0.12 log units) below the measured one; the measured number falls inside the stated range.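

Within the data shown here, compound 4 gives 3920 nM in this assay, but compound 3 has no single number among the values shown, so no step from compound 3 to compound 4 can be read. The compounds shown leave open how pyrimidin-5-yl in place of thiophen-2-yl shifts antiproliferative activity on this read-out, in either direction.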